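Swapping chloro for methoxy on a second vinyl-linked phenyl ring

The compounds below may be only part of what the source reports. "The series", "measured", "known", "first", "only" and "open" are said of these compounds alone.

Measured compounds:
compound 1 `COc1cccc(/C=C2\CCC/C(=C\c3cccc(Cl)c3)C2=O)c1OC` gives 9100 nM
compound 2 `COc1cccc(/C=C2\CCC/C(=C\c3cccc(OC)c3OC)C2=O)c1` gives 7000 nM
compound 3 `COc1cccc(/C=C2\CCC/C(=C\c3ccc(O)c(Cl)c3)C2=O)c1OC` gives 16800 nM

These three compounds share one core and were tested in a functional assay on SW-620 cells (Homo sapiens) for cytotoxicity, read by MTT assay, with a stated time of 72 h; on this read-out higher numbers stand for weaker inhibition and lower numbers for stronger inhibition. The change from compound 1 to compound 2 is methoxy in place of chloro on an aromatic carbon and it gave a 1.3-fold lower number from compound 1 to compound 2 (0.11 log units; within the scatter). Compound 4 `COc1cc(/C=C2\CCC/C(=C\c3cccc(OC)c3OC)C2=O)ccc1O` is not yet measured; it arises from compound 3 by methoxy in place of chloro on an aromatic carbon, the same kind of change. The two cores differ by hydroxy in place of hydrogen on an aromatic carbon, so compound 3 and compound 4 carry a hydroxy group that compound 1 and compound 2 lack. The surroundings of the change also differ: in compound 1 the chloro sits meta to a large group, while in compound 3 it sits ortho to a hydroxy group and meta to a large group. Given a 1.3-fold lower number from compound 1 to compound 2 (0.11 log units; within the scatter), the step of a 1.3-fold lower number from compound 3 to compound 4 (0.11 log units; within the scatter) is expected to be small as well, since the earlier change barely moved the number. The estimate for compound 4 in this assay is therefore 13000 nM, with a range from 6000 nM to 28000 nM.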

Compound 4, half-maximal inhibitory concentration: 8600 nM
The estimate for compound 4 lay 1.5-fold (0.18 log units) above the measured number; the range from low to high includes it.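

In this assay, methoxy in place of chloro gives a 2.0-fold lower number from compound 3 to compound 4 (0.29 log units; within the scatter), and this step agrees with the one seen for the same swap on the core without the hydroxy group: the same change on two cores in this assay, a 1.3-fold lower number (0.11 log units; within the scatter) from compound 1 to compound 2 and a 2.0-fold lower number (0.29 log units; within the scatter) from compound 3 to compound 4, 1.5-fold (0.18 log units) apart, within the scatter of two such steps

The hydroxy group also carries across the two cores, with a 1.2-fold higher number from compound 2 to compound 4 (0.09 log units; within the scatter) set beside its earlier step: the same change on two cores in this assay, a 1.8-fold higher number (0.27 log units; within the scatter) from compound 1 to compound 3 and a 1.2-fold higher number (0.09 log units; within the scatter) from compound 2 to compound 4, 1.5-fold (0.18 log units) apart, within the scatter of two such steps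

The larger swap of 3-chlorophenyl to 4-hydroxy-3-methoxyphenyl gives a 1.1-fold lower number from compound 1 to compound 4 (0.02 log units; within the scatter), so all three new steps stay within the scatter; this shows that the swap stays small on both cores here, but two pairs of small steps cannot separate a slight real effect from none, and they set no rule for cores beyond these.

On these data alone, whether an amine or a carboxylic acid at the same place on the ring would give a step beyond the scatter remains open. So does whether a longer chain in place of the methoxy would do so.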